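The compounds below may be only part of what the source reports. "The series", "measured", "known", "first", "only" and "open" are said of these compounds alone.

Compound 1 `CC(C)(C)c1cc(NC(=O)Nc2ccc(-c3cn4ccccc4n3)cc2)no1` is the stronger of the two compounds measured in a functional assay on MV4-11 cells (Homo sapiens) for cytotoxicity, read by MTT assay, with a stated time of 72 h; a lower number here means a stronger inhibitor, a higher number a weaker inhibitor: compound 1 gives 3.09 nM, while compound 2 `CC(C)(C)c1cc(NC(=O)Nc2ccc(-c3cc4ccccc4o3)cc2)no1` gives 195 nM. Among the compounds with values here, the one measured step, a 63-fold higher number from compound 1 to compound 2 (1.80 log units; beyond the scatter), swaps one pair of fused rings for a different pair and so bears only loosely on the change to compound 3 `CC(C)(C)c1cc(NC(=O)Nc2ccc(-c3cn4cc(F)ccc4n3)cc2)no1`, which keeps the fused rings of compound 1 and differs only by fluoro in place of hydrogen on an aromatic carbon. Within the data shown here, no measured pair shows what a single fluoro on this ring does, so the expectation rests on how small the change is. A step of a 1.1-fold higher number from compound 1 to compound 3 (0.05 log units; within the scatter) is expected, that is, no change beyond the usual scatter. Compound 3 is therefore estimated at 3.5 nM in this assay, with a likely range from 1 nM to 12 nM.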

Compound 3, half-maximal inhibitory concentration: 20.9 nM
Compound 3: middle estimate off by 6.0-fold (0.78 log units), on the low side; the measured number lies above the stated range.
By their numbers in this assay, from the lowest: compound 1; then compound 3; then compound 2.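

In this assay, the fluoro that compound 3 carries on an aromatic carbon, two atoms from the ring nitrogen, is not a silent change: it gives a 6.8-fold higher number from compound 1 to compound 3 (0.83 log units; beyond the scatter). The earlier pair showed that exchanging the whole pair of fused rings matters, whereas this pair shows that a change of one heavy atom on those rings can also move the number beyond the scatter. Nothing available explains the weaker result for compound 3.

On these data alone, it remains open whether this drop is specific to fluoro or would follow any group at this carbon, a question that a chloro, methyl or methoxy group there could help answer. As far as these compounds go, it is also open whether fluoro on another carbon of the same ring would give a similar step.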